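Shortening a Side Chain from Butyl to Methyl

The compounds below may be only part of what the source reports. "The series", "measured", "known", "first", "only" and "open" are said of these compounds alone.

Compound 1: `OC[C@@]1(c2ccc(O)cc2)NC[C@@H](O)[C@@H]1O`, 11000 nM
Compound 2: `CCCC[C@@]1(CO)NC[C@H](O)[C@H]1O`, 220 nM

For the measured compounds named here, in an assay on isolated protein for inhibition of lysosomal alpha-glucosidase (Rattus norvegicus), read by colorimetric assay (a higher number here means a weaker inhibitor, a lower number a stronger inhibitor), compound 2 gives 220 nM, the lower of the two numbers measured so far, while compound 1 gives 11000 nM. That gap lies well beyond the usual scatter, but the two structures differ in several places at once, so no single change can be read from it.

Compound 3, `C[C@@]1(CO)NC[C@H](O)[C@H]1O`, has not yet been measured. It comes from compound 2 by one change: hydrogen in place of propyl on a saturated chain carbon bound to a saturated ring carbon. Going by the values given here, no measured pair isolates such a change, so the expectation rests on compound 2 alone at 220 nM. Removing three carbon atoms from the chain is expected to weaken inhibition, a step of about a 5.5-fold higher number from compound 2 to compound 3 (0.74 log units; beyond the scatter) toward a higher number. Compound 3 is estimated at 1200 nM, with a likely range from 300 nM to 5000 nM.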

Compound 3, half-maximal inhibitory concentration: 2900 nM
Compound 3: the middle estimate sits 2.4-fold (0.38 log units) below what was measured; the measured number falls inside the stated range.
By their numbers in this assay, from the lowest: compound 2; then compound 3; then compound 1.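

For the compounds shown here, this pair gives the first clean reading at this position: in this assay, hydrogen in place of propyl on a saturated chain carbon bound to a saturated ring carbon, which turns butyl into methyl, gives a large step (a 13-fold higher number from compound 2 to compound 3 (1.12 log units; beyond the scatter)). Going by these compounds alone, compound 1 could not show this, since it differs from compound 2 in several places at once, whereas here the chain is the only thing that changes, and the butyl compound is clearly the stronger inhibitor of the pair. Nothing measured here gives a reason for the size of this step.

Within the data shown here, only two chain lengths can be compared, so it remains open whether ethyl or propyl would fall between them. On these data alone, it is also open whether a longer chain, such as hexyl, or a butyl chain ending in an amine would lower the number further.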